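Methyl to Fluoro on a Shared Core: Compound 4 Awaited

This account rests on a few compounds, and the source may have more. Where it says the series, first, only, none or still open, it means among the compounds named here.

Three compounds have been measured in a functional assay on HeLa cells (Homo sapiens) for cytotoxicity, read by MTT assay, with a stated time of 2 days; a higher number here means a weaker inhibitor, a lower number a stronger inhibitor:

Compound 1 `Cc1cccc(-c2nc3cc(C)ccc3c(=O)[nH]2)c1`: 11200 nM
Compound 2 `Cc1ccc2nc(-c3ccccc3C)[nH]c(=O)c2c1`: 4580 nM
Compound 3 `Cc1ccc2nc(-c3ccccc3F)[nH]c(=O)c2c1`: > 50000 nM, a limit of this assay

Compound 1 and compound 2 are built from the same atoms joined differently; the difference between the two cores is not broken down here. Of the two, compound 1 gives the higher number, beyond the scatter. Compound 3 reports only a limit (the limit of > 50000 nM in this assay, at which 1 of the 3 values shown sits). The step of an at least 10-fold higher number from compound 2 to compound 3 (1.03 log units; beyond the scatter) comes from fluoro in place of methyl on an aromatic carbon.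

Compound 4 `Cc1ccc2c(=O)[nH]c(-c3cccc(F)c3)nc2c1` has not yet been measured. It differs from compound 1 by fluoro in place of methyl on an aromatic carbon. This is the same kind of change as that from compound 2 to compound 3, but not the same: there the fluoro sits ortho to a large group, here meta to a large group. Resting on the step of an at least 10-fold higher number from compound 2 to compound 3 (1.03 log units; beyond the scatter), a step of a 5.4-fold higher number from compound 1 to compound 4 (0.73 log units; beyond the scatter) is expected. Compound 4 is therefore estimated at 60000 nM, within a range from 20000 nM to 200000 nM.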

Compound 4, half-maximal inhibitory concentration: > 50000 nM
Compound 4: only a limit was reported (the forecaster's own chance of this, stated with the estimate: 55%); the middle value is on the limit's open side.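

Compound 4 gives > 50000 nM in this assay, which is a limit and not a number, and it shares that limit with compound 3: the limit of > 50000 nM in this assay, at which 2 of the 4 values shown sit. On the core of compound 1, fluoro in place of methyl on an aromatic carbon gives an at least 4.4-fold higher number from compound 1 to compound 4 (0.64 log units; beyond the scatter), so the number moves in the same direction on both cores, towards a weaker inhibitor, and that direction carries over in this pair of cores. What this does not show is whether the size of the change carries over as well: the same change on two cores in this assay, an at least 10-fold higher number (1.03 log units; beyond the scatter) from compound 2 to compound 3 and an at least 4.4-fold higher number (0.64 log units; beyond the scatter) from compound 1 to compound 4; the limit leaves it open whether they differ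

On these data alone, neither fluoro compound has an exact value, so how far each one lies from its methyl partner remains open. Methyl and fluoro are also the only groups shown at these places, which leaves open where a chlorine, a methoxy group, an amine or a carboxylic acid in the same place would fall in this assay.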